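A Small Swap on the Outer Ring: Bromo to Methyl

The source may report more compounds than this note shows. Statements on the series, on what has been measured and on what is new or still open speak of the compounds shown alone.

Two compounds have been measured in a functional assay on MCF7 cells (Homo sapiens) for cytotoxicity, read by MTT assay, with a stated time of 72 h; a lower number here means a stronger inhibitor, a higher number a weaker inhibitor:
compound 1 `O=C(Nc1ccc(Oc2ccnc3[nH]ccc23)cc1)c1cc(-c2ccc(C(F)(F)F)cc2)ncn1` gives 6240 nM;
compound 2 `O=C(Nc1ccc(Oc2ccnc3[nH]ccc23)cc1)c1cc(-c2ccc(Br)cc2)ncn1` gives 3840 nM.

Compound 2 has the smaller of the two numbers shown, with compound 1 as its only neighbour, but the step of a 1.6-fold lower number from compound 1 to compound 2 (0.21 log units; within the scatter) is within the scatter, so the two cannot be ranked against each other. Compound 3 `Cc1ccc(-c2cc(C(=O)Nc3ccc(Oc4ccnc5[nH]ccc45)cc3)ncn2)cc1` keeps the shared core and differs from compound 2 in one place: methyl in place of bromo on an aromatic carbon. For the measured compounds named here, only one measured step bears on this change, the step of a 1.6-fold lower number from compound 1 to compound 2 (0.21 log units; within the scatter), which also exchanged one small group for another at that aromatic carbon and stayed within the scatter. With no measured step beyond the scatter pointing either way, the expected step of a 1.0-fold higher number from compound 2 to compound 3 (0.02 log units; within the scatter) is none beyond the scatter. Compound 3 is therefore estimated at 4000 nM in this assay, with a range from 1800 nM to 9000 nM.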

Compound 3, half-maximal inhibitory concentration: 1620 nM
Compound 3: the middle estimate sits 2.5-fold (0.39 log units) above what was measured, outside the stated range (below it).
By their numbers in this assay, from the lowest: compound 3; then compounds 2 and 1 (each within the scatter of the next).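

In this assay, for the compounds shown here, the change to methyl gives the first step at this aromatic carbon that lies beyond the scatter (a 2.4-fold lower number from compound 2 to compound 3 (0.37 log units; beyond the scatter)), and the step against trifluoromethyl is larger (a 3.9-fold lower number from compound 1 to compound 3 (0.59 log units; beyond the scatter)). The group at this carbon can therefore shift the number, which the pair of compound 1 and compound 2 alone could not show, although both new steps are modest and that earlier pair still cannot be ranked. Nothing shown here gives a reason for the difference.

Still open, as far as these compounds go, is whether an ethyl group, a methoxy group or an amine at this carbon would give a lower or a higher number than methyl. Also open, from the compounds shown here alone, is whether the order seen with these three compounds holds on any other cell line.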